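From Fluoro to Chloro: A Small Change Tested

This account rests on a few compounds, and the source may have more. Where it says the series, first, only, none or still open, it means among the compounds named here.

Among the compounds with values here, compound 2 `O=C(O)Cc1sc(C(c2ccc(F)cc2)c2ccc(F)cc2)nc1-c1ccnc(F)c1` gives the lowest number of the two measured so far in an in vitro functional assay on HEK285-7 cells for antagonist activity at prostaglandin D2 receptor 2 (Homo sapiens), read by BRET and beta-arrestin recruitment (on this read-out lower numbers stand for stronger inhibition and higher numbers for weaker inhibition), at 4.7 nM. Compound 1 `N#Cc1ccc(-c2nc(C(c3ccc(F)cc3)c3ccc(F)cc3)sc2CC(=O)O)cc1` gives 1500 nM in this assay, and the step of a 320-fold lower number from compound 1 to compound 2 (2.50 log units; beyond the scatter) is large; it came from 2-fluoropyridin-4-yl in place of 4-cyanophenyl. Compound 3 `O=C(O)Cc1sc(C(c2ccc(F)cc2)c2ccc(F)cc2)nc1-c1ccnc(Cl)c1` differs from compound 2 by chloro in place of fluoro on an aromatic carbon, the chloro sitting next to the ring nitrogen, meta to a large group. Within the data shown here, no measured step involves a change of this kind, so the data give no direct guidance. The step from compound 2 to compound 3 is expected to be a 1.1-fold higher number from compound 2 to compound 3 (0.03 log units; within the scatter), within the scatter. Compound 3 is estimated to give 5 nM in this assay, between 2 nM and 15 nM.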

Compound 3, half-maximal inhibitory concentration: 39 nM
The estimate for compound 3 lay 7.8-fold (0.89 log units) below the measured number; the measured number lies above the stated range.
By their numbers in this assay, from the lowest: compound 2; then compound 3; then compound 1.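

In this assay, exchanging a single atom on the 2-fluoropyridin-4-yl group gives an 8.3-fold higher number from compound 2 to compound 3 (0.92 log units; beyond the scatter), so this position is sensitive to which halogen it carries. Chloro still keeps much of the advantage over the 4-cyanophenyl group, with a 38-fold lower number from compound 1 to compound 3 (1.59 log units; beyond the scatter). Nothing here accounts for the gap between fluoro and chloro. As far as these compounds go, whether a methyl, a methoxy or an amine at this place would match fluoro remains open. Also open, from the compounds shown here alone, is what the ring nitrogen contributes on its own, apart from the halogen.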